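The source may report more compounds than this note shows. Statements on the series, on what has been measured and on what is new or still open speak of the compounds shown alone.

Measured in a functional assay on HCT-116 cells (Homo sapiens), read by sulforhodamine B assay, with a stated time of 5 days; a lower number here means a stronger inhibitor of growth, a higher number a weaker inhibitor of growth:
compound 1 `OC[C@H]1O[C@@H](n2cc(F)c3c(-c4ccsc4)ncnc32)[C@H](O)[C@@H]1O`: 140 nM
compound 2 `OC[C@H]1O[C@@H](n2cc(Cl)c3c(-c4ccco4)ncnc32)[C@H](O)[C@@H]1O`: > 10000 nM, a limit
compound 3 `OC[C@H]1O[C@@H](n2cc(Cl)c3c(-c4ccoc4)ncnc32)[C@H](O)[C@@H]1O`: 2000 nM

Compound 3, at 2000 nM, holds the higher of the two numeric values, and compound 1 stands lower at 140 nM. Compound 2 gives only a limit, > 10000 nM.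

Compound 4 `OC[C@H]1O[C@@H](n2cc(Cl)c3c(-c4ccsc4)ncnc32)[C@H](O)[C@@H]1O` departs from compound 3 by one exchange: thiophen-3-yl in place of furan-3-yl on an aromatic carbon. For the measured compounds named here, no measured step makes this exchange directly. The closest is an at least 5.0-fold lower number from compound 2 to compound 3 (0.69 log units; beyond the scatter), furan-3-yl in place of furan-2-yl, which shows that the group at this place can move this assay beyond the scatter. Going by the values given here, compound 1, the only measured compound with thiophen-3-yl, gives 140 nM, although its core carries fluorine where compound 3 carries chlorine. On the strength of that value, a lower number beyond the scatter is expected. The expected size is a 10-fold lower number from compound 3 to compound 4 (1.00 log units; beyond the scatter). For compound 4 the estimated value is 200 nM, with an expected range of 60 nM to 700 nM.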

Compound 4, concentration for 50% growth inhibition: 100 nM
The estimate for compound 4 lay 2.0-fold (0.30 log units) above the measured number, within the range that was stated.
By their numbers in this assay, from the lowest: compounds 4 and 1 (each within the scatter of the next); then compound 3. At a limit, above all of these: compound 2.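

In this assay, for the compounds shown here, with chloro held on the shared core, thiophen-3-yl in place of furan-3-yl gives a 20-fold lower number from compound 3 to compound 4 (1.30 log units; beyond the scatter), so the identity of the hetero atom in this five-membered aromatic ring moves the number on its own, a change the earlier compounds did not isolate. Thiophen-3-yl in place of furan-2-yl gives an at least 100-fold lower number from compound 2 to compound 4 (2.00 log units; beyond the scatter), and this step rests on a limit, not a number: the limit of > 10000 nM in this assay, at which 1 of the 4 values shown sits.
With thiophen-3-yl held in place, chloro in place of fluoro gives a 1.4-fold lower number from compound 1 to compound 4 (0.15 log units; within the scatter), so these two halogens are not told apart in this setting.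

The compounds shown leave open how thiophen-2-yl, phenyl or an amine would behave at this place. On these data alone, whether bromo or a hydrogen on the core would keep the number of compound 4 also remains open.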